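The source may report more compounds than this note shows. Statements on the series, on what has been measured and on what is new or still open speak of the compounds shown alone.

Measured in a physicochemical assay for solubility, read by HPLC; a lower number here means a less soluble compound, a higher number a more soluble compound:
compound 1 `CC(=O)N1CCN(c2nc(=O)c3cc(C(F)(F)F)cc([N+](=O)[O-])c3s2)CC1` gives 83.9 ug/mL
compound 2 `CCC(C)C(=O)N1CCN(c2nc(=O)c3cc(C(F)(F)F)cc([N+](=O)[O-])c3s2)CC1` gives 104 ug/mL

Going by the values given here, compound 2 stands at the upper of the two numbers in this assay, but the only step to it, a 1.2-fold higher number from compound 1 to compound 2 (0.09 log units; within the scatter), falls inside the scatter, so the two cannot be ordered. Compound 3 `O=C(C1CCCCC1)N1CCN(c2nc(=O)c3cc(C(F)(F)F)cc([N+](=O)[O-])c3s2)CC1` awaits measurement. The change is cyclohexyl in place of sec-butyl on a carbonyl carbon. Among the compounds with values here, the one step that bears on it, a 1.2-fold higher number from compound 1 to compound 2 (0.09 log units; within the scatter), also exchanged the group on the carbonyl carbon and moved nothing beyond the scatter. Compound 3 is therefore expected to shift little, with at most a slight drop, as a 1.6-fold lower number from compound 2 to compound 3 (0.20 log units; within the scatter). Compound 3 is estimated at 65 ug/mL, range 25 ug/mL to 150 ug/mL.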

Compound 3, solubility: 3.24 ug/mL
The estimate for compound 3 lay 20-fold (1.30 log units) above the measured number; measured number outside the range, below it.
By their numbers in this assay, from the lowest: compound 3; then compounds 1 and 2 (each within the scatter of the next).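

The group on the carbonyl carbon is not indifferent in this assay: cyclohexyl in place of sec-butyl gives a 32-fold lower number from compound 2 to compound 3 (1.51 log units; beyond the scatter), and cyclohexyl in place of methyl gives a 26-fold lower number from compound 1 to compound 3 (1.41 log units; beyond the scatter). Methyl and sec-butyl remain within the scatter of each other, so among these three compounds only cyclohexyl separates from the others. No measurement shown here explains the drop.

From the compounds shown here alone, it remains open whether the drop goes with the ring or with the size of the group. A longer open chain such as n-hexyl and a smaller ring such as cyclopropyl, on the same carbonyl carbon, would help separate the two.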